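This account rests on a few compounds, and the source may have more. Where it says the series, first, only, none or still open, it means among the compounds named here.

Measured compounds:
compound 1 `Nc1ccc(C(=O)/C=C/c2ccc3c(c2)B(O)OC3)cc1`: 25800 nM
compound 2 `O=C(/C=C/c1ccc2c(c1)B(O)OC2)c1ccc([N+](=O)[O-])cc1`: 11200 nM
compound 3 `COc1cc(C(=O)/C=C/c2ccc3c(c2)B(O)OC3)ccc1[N+](=O)[O-]`: 11400 nM

All three numbers come from a functional assay on MDA-MB-231 cells (Homo sapiens) for cytotoxicity, read by MTT assay, with a stated time of 48 h; a higher number here means a weaker inhibitor, a lower number a stronger inhibitor. Compound 4 `COc1cc(C(=O)/C=C/c2ccc3c(c2)B(O)OC3)ccc1N` has not yet been measured there.

Compound 2 and compound 1 differ by amino in place of nitro on an aromatic carbon, and this change gave a 2.3-fold higher number from compound 2 to compound 1 (0.36 log units; beyond the scatter). Compound 3 and compound 4 differ by amino in place of nitro on an aromatic carbon. The two cores differ by methoxy in place of hydrogen on an aromatic carbon, a change that gave a 1.0-fold higher number from compound 2 to compound 3 (0.01 log units; within the scatter). Around the place, in compound 3 the change sits ortho to a methoxy group (2 heavy atoms) and para to a large group, whereas in compound 2 it sits only para to a large group; the two changes are the same kind of change, not the same. For the measured compounds named here, the expected step is a 2.3-fold higher number from compound 3 to compound 4 (0.36 log units; beyond the scatter), resting on the single observed step of this kind, a 2.3-fold higher number from compound 2 to compound 1 (0.36 log units; beyond the scatter). Compound 4 is accordingly estimated at about 26000 nM, within 12000 nM to 55000 nM.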

Compound 4, half-maximal inhibitory concentration: 24300 nM
For compound 4 the middle estimate is 1.1-fold (0.03 log units) above the measured one; the range from low to high includes it.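

In this assay, amino in place of nitro gave a 2.1-fold higher number from compound 3 to compound 4 (0.33 log units; beyond the scatter), and this step agrees with the one on the core lacking the methoxy group: the same change on two cores in this assay, a 2.3-fold higher number (0.36 log units; beyond the scatter) from compound 2 to compound 1 and a 2.1-fold higher number (0.33 log units; beyond the scatter) from compound 3 to compound 4, 1.1-fold (0.03 log units) apart, within the scatter of two such steps

Methoxy in place of hydrogen, now read with amino rather than nitro in the same place, gave a 1.1-fold lower number from compound 1 to compound 4 (0.03 log units; within the scatter), and the two methoxy steps also agree: the same change on two cores in this assay, a 1.0-fold higher number (0.01 log units; within the scatter) from compound 2 to compound 3 and a 1.1-fold lower number (0.03 log units; within the scatter) from compound 1 to compound 4, 1.1-fold (0.03 log units) apart, within the scatter of two such steps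

This shows the two changes carrying over between these four compounds in this one cell assay, but it does not show that they would carry over to a core that differs more widely, nor why the steps agree.

Open, on these data alone, is how an acetamide, a dimethylamino group or a carboxylic acid in place of the amino group would read in this assay. Also open, as far as these compounds go, is whether an ethoxy group or a chlorine atom in place of the methoxy group would behave as methoxy does.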